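A few compounds are considered here, and "the series" means these few. Any claim that something is new, unique, unknown or untested is made for them only; others in the source may bear on it.

Compound 1 `CC(C)N(Cc1cccc(OCCCCCC(=O)O)c1)C(=O)c1ccccc1` and compound 2 `CCOC(=O)CCCCCOc1cccc(CN(C(=O)c2ccccc2)C(C)C)c1` share one core and differ only at the chain end. In an ADME assay on BJ cells (Homo sapiens) for cytotoxicity, read by CellTiter-Glo and resazurin assay, with a stated time of 72 h (a higher number here means that more compound is needed for the effect, a lower number that less compound is needed), compound 1 gives only a limit, > 26000 nM. In this assay compound 2 likewise gives only a limit, > 26000 nM. The step from compound 1 to compound 2 a step that the two limits leave unreadable from compound 1 to compound 2, ethyl in place of hydrogen on an oxygen next to a carbonyl group, cannot be sized because both of its ends sit at the limit of > 26000 nM in this assay, at which 2 of the 2 values shown sit. For the measured compounds named here, compound 2 thus stands at the limit of this assay, where the one other value also stands.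

Compound 3 `CCOC(=O)CCCCCOc1cccc(CN(C(=O)c2ccc(-c3cccnc3)cc2)C(C)C)c1` differs from compound 2 by pyridin-3-yl in place of hydrogen on an aromatic carbon of a six-membered aromatic ring of carbon only, para to a large group; cut one bond further out, phenyl becomes 4-(pyridin-3-yl)phenyl. Going by the values given here, no measured step touches this ring, and the single measured step is unreadable. The expectation for compound 3 is therefore only that this assay again reports a limit, an estimated step from compound 2 to compound 3 of a step that the limit leaves unreadable from compound 2 to compound 3. The estimate for compound 3 is 30000 nM, in the range 10000 nM to 100000 nM.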

Compound 3, half-maximal effective concentration: > 26000 nM
Compound 3: a limit, no number; the forecaster's own chance of this, stated with the estimate: 75%; the middle value does not contradict the limit.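

No new step can be read: compound 2 and compound 3 both give only a limit in this assay, which leaves the step between them without a size, because all the values share one limit: the limit of > 26000 nM in this assay, at which 3 of the 3 values shown sit.

The compounds shown leave open whether the chain end or pyridin-3-yl changes the half-maximal effective concentration in this assay at all.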